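A few compounds are considered here, and "the series" means these few. Any claim that something is new, unique, unknown or untested is made for them only; others in the source may bear on it.

Compound 1 `O=C(Nc1cccc(-n2cc(-c3ccncc3)c(-c3ccc(Cl)c(O)c3)n2)c1)Nc1cc(C(F)(F)F)cc(C(F)(F)F)c1` gives 1900 nM in a functional assay on UO-31 cells (Homo sapiens) for inhibition, read by sulforhodamine B assay, with a stated time of 48 h; a lower number here means a stronger inhibitor of growth, a higher number a weaker inhibitor of growth.
Compound 2 `COc1cc(-c2nn(-c3cccc(NC(=O)Nc4cccc(C(F)(F)F)c4)c3)cc2-c2ccncc2)ccc1Cl` gives 3210 nM in this assay.

These two numbers are all that has been measured so far. Compound 2 has the higher of the two, and the nearest number belongs to compound 1, whose result sits within the usual scatter of this kind of measurement, so the two compounds cannot be told apart on the data at hand. For the measured compounds named here, no step between measured compounds that differ in a single place is available, and the structures of compound 1 and compound 2 differ in more than one place.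

Compound 3 `COc1cc(-c2nn(-c3cccc(NC(=O)c4ccccc4)c3)cc2-c2ccncc2)ccc1Cl` has not yet been tested. It differs from compound 2 in one place: phenyl in place of (3-(trifluoromethyl)phenyl)amino on a carbonyl carbon. The urea of compound 2 thus becomes a plain benzamide in compound 3. Going by the values given here, with no single-point step to lean on, any expectation rests on the position of compound 2 alone. The step from compound 2 to compound 3 is expected to be a 2.2-fold higher number from compound 2 to compound 3 (0.34 log units; beyond the scatter), a moderate move toward a weaker growth inhibitor, though a result within the scatter would not be surprising. Compound 3 is therefore estimated at 7000 nM in this assay, with a range from 2500 nM to 25000 nM.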

Compound 3, concentration for total growth inhibition: > 100000 nM
Compound 3 ended at the assay's limit; the forecaster's own chance of this, stated with the estimate: 15%; middle value at least 14-fold (1.15 log units) from the limit.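

For the compounds shown here, the step at this position is the first single-place comparison in this assay: with phenyl in place of (3-(trifluoromethyl)phenyl)amino on a carbonyl carbon, the result is an at least 31-fold higher number from compound 2 to compound 3 (1.49 log units; beyond the scatter). Compound 3 gives > 100000 nM, which is a limit of the assay and not a number. Compound 1 and compound 2 differ in more than one place and could not show whether this position matters, whereas this exchange shows that the growth inhibition of compound 2 depends strongly on what sits on this carbonyl carbon, though the full size of the step remains unknown: the limit of > 100000 nM in this assay, at which 1 of the 3 values shown sits.

The exchange removes the amino nitrogen and the trifluoromethyl group together, so the compounds shown do not separate the contribution of one from that of the other. On these data alone, it remains open whether a plain phenylamino group, which keeps the urea without the trifluoromethyl, or a 3-(trifluoromethyl)phenyl group on the same carbonyl carbon, which keeps the trifluoromethyl in a benzamide, would retain any of the growth inhibition seen with compound 2.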